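A 4-fluorophenyl swap in a small antiproliferative series

The source may report more compounds than this note shows. Statements on the series, on what has been measured and on what is new or still open speak of the compounds shown alone.

Compound 1 `CC(=O)N1N=C(c2ccc3ccccc3c2)OC1c1ccccc1`: 2.11 ug/mL
Compound 2 `CC(=O)N1N=C(c2ccc3ccccc3c2)OC1c1cccc(Br)c1`: 1.68 ug/mL
Compound 3 `CC(=O)N1N=C(c2ccc3ccccc3c2)OC1c1ccccc1Cl`: 4.32 ug/mL

These three values come from a functional assay on HepG2 cells (Homo sapiens) for antiproliferative activity, read by MTT assay, with a stated time of 48 h; on this read-out higher numbers stand for weaker inhibition and lower numbers for stronger inhibition. Compound 3 stands highest of the three, making it the weakest inhibitor measured so far. Compound 4 `CC(=O)N1N=C(c2ccc3ccccc3c2)OC1c1ccc(F)cc1` has not yet been measured. It differs from compound 3 as follows: 4-fluorophenyl in place of 2-chlorophenyl on a saturated ring carbon. In words, 4-fluorophenyl replaces 2-chlorophenyl on a saturated ring carbon.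

Among the measured compounds shown here, three measured steps bear on this change. Chloro in place of hydrogen gave a 2.0-fold higher number from compound 1 to compound 3 (0.31 log units; beyond the scatter), and 2-chlorophenyl in place of 3-bromophenyl gave a 2.6-fold higher number from compound 2 to compound 3 (0.41 log units; beyond the scatter). Bromo in place of hydrogen gave only a 1.3-fold lower number from compound 1 to compound 2 (0.10 log units; within the scatter). For the measured compounds named here, no fluorinated compound has been measured, so the size of the fluoro step remains unknown.

Since compound 4 loses the 2-chlorophenyl, its number is expected to return towards those of compound 1 and compound 2. In this assay, a modest step to a lower number is expected, estimated as a 2.0-fold lower number from compound 3 to compound 4 (0.29 log units; within the scatter). For compound 4 the estimated value is 2.2 ug/mL, with an expected range from 1.1 ug/mL to 4.2 ug/mL.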

Compound 4, half-maximal inhibitory concentration: 1.82 ug/mL
The estimate for compound 4 lay 1.2-fold (0.08 log units) above the measured number, and the stated range covers the measured number.
By their numbers in this assay, from the lowest: compounds 2, 4 and 1 (each within the scatter of the next); then compound 3.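

In this assay, replacing 2-chlorophenyl with 4-fluorophenyl on the saturated ring carbon gives a 2.4-fold lower number from compound 3 to compound 4 (0.38 log units; beyond the scatter), the first sign that a halogen on this phenyl ring can leave the number close to that of the unsubstituted phenyl compound. The fluoro step gives a 1.2-fold lower number from compound 1 to compound 4 (0.06 log units; within the scatter) and the swap from 3-bromophenyl gives a 1.1-fold higher number from compound 2 to compound 4 (0.03 log units; within the scatter), both within the scatter, so among these four compounds only compound 3 stands apart, as the weakest inhibitor. Nothing available accounts for this difference.

The compounds shown leave open whether the higher number of compound 3 follows from the chloro group itself or from where it sits on the phenyl ring, a question that 4-chlorophenyl and 2-fluorophenyl groups could separate. From the compounds shown here alone, it also remains open whether an amine or a carboxylic acid on this phenyl ring would keep the number in the same range.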